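From dimethylamino to pyrrolidin-1-yl on the side chain

This account rests on a few compounds, and the source may have more. Where it says the series, first, only, none or still open, it means among the compounds named here.

Within the data shown here, in a functional assay on LNCaP cells (Homo sapiens) for antiproliferative activity (on this read-out lower numbers stand for stronger inhibition and higher numbers for weaker inhibition), compound 2 (`CN(C)CC[C@@H]1C[C@@H](c2ccc(Cl)c(Cl)c2)[C@H](NC(=O)c2cc(-c3c(Cl)cnn3C)c(Cl)o2)CN1`) gives 1930 nM, the higher of two numbers so far, while compound 1 (`Cn1ncc(Cl)c1-c1cc(C(=O)N[C@@H]2CN[C@H](CC(=O)O)C[C@H]2c2ccc(Cl)c(Cl)c2)oc1Cl`) gives 640 nM. Compound 3 (`Cn1ncc(Cl)c1-c1cc(C(=O)N[C@@H]2CN[C@H](CCN3CCCC3)C[C@H]2c2ccc(Cl)c(Cl)c2)oc1Cl`) carries pyrrolidin-1-yl in place of dimethylamino on a saturated chain carbon, two bonds along the chain from a saturated ring carbon. Among the measured compounds shown here, only one measured step touches this chain, a 3.0-fold higher number from compound 1 to compound 2 (0.48 log units; beyond the scatter), which is modest and replaces carboxy, so it offers only a loose guide. For the measured compounds named here, no measured step exchanges one ring-free amino group for a ring. In this assay, no change beyond the scatter is expected: the estimated step is a 1.1-fold lower number from compound 2 to compound 3 (0.06 log units; within the scatter). For compound 3, the expected value is 1700 nM, with an estimated range of 800 nM to 3600 nM.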

Compound 3, half-maximal inhibitory concentration: 1920 nM
Estimate against measurement, compound 3: 1.1-fold (0.05 log units) below; the measured number falls inside the stated range.
By their numbers in this assay, from the lowest: compound 1; then compounds 3 and 2 (each within the scatter of the next).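

In this assay pyrrolidin-1-yl in place of dimethylamino on this chain changes nothing measurable (a 1.0-fold lower number from compound 2 to compound 3 (0.00 log units; within the scatter)), so a ring on this amine nitrogen and its larger group of heavy atoms leave the number where it was. The gap to the carboxy compound (a 3.0-fold higher number from compound 1 to compound 3 (0.48 log units; beyond the scatter)) therefore stays the same with either amine. No measured evidence accounts for these steps.

Still open, on these data alone, is how a piperidin-1-yl or morpholin-4-yl group, or an unsubstituted primary amine, would read on this chain. As far as these compounds go, a longer chain between the saturated ring carbon and the amine also remains open.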